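Notes on the step from compound 2 to compound 3

The compounds below may be only part of what the source reports. "The series", "measured", "known", "first", "only" and "open" are said of these compounds alone.

Measured so far in a functional assay on the whole organism with Rattus norvegicus as the target (a higher number here means that more compound is needed for the effect, a lower number that less compound is needed), for two compounds:
- compound 1 `CCOCCOC(=O)C(=O)Nc1nc(-c2cc(COC)no2)cs1` gives 2.4 mg/kg
- compound 2 `CCOCCOC(=O)C(=O)Nc1nc(-c2cc(CO)on2)cs1` gives 1.8 mg/kg

In this assay, within the data shown here, compound 2 stands level with compound 1, the single measured step (a 1.3-fold lower number from compound 1 to compound 2 (0.12 log units; within the scatter)) lying within the scatter. The next compound, compound 3 `O=C(O)C(=O)Nc1nc(-c2cc(CO)on2)cs1`, keeps the rest of compound 2 and has hydrogen in place of 2-ethoxyethyl on an oxygen next to a carbonyl group. The same difference reads 2-ethoxyethoxy to hydroxy.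

Among the measured compounds shown here, the one measured step does not bear directly on this change, as it is a replacement on an aromatic carbon at another place. For the measured compounds named here, no measured pair shows this replacement, so the data give neither a size nor a direction for it. From the compounds shown here alone, no step beyond the scatter is predicted, but a large one either way remains open, and the range is kept wide.

Compound 3 is estimated at 2.5 mg/kg (expected range 0.4 mg/kg to 15 mg/kg). This estimate means an expected 1.4-fold higher number from compound 2 to compound 3 (0.14 log units; within the scatter) as a loose working figure.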

Compound 3, dose for half-maximal effect: > 100 mg/kg
Compound 3: a limit, no number; the forecaster's own chance of this, stated with the estimate: 15%; at least 40-fold (1.60 log units) between middle value and limit.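

The 2-ethoxyethyl on an oxygen next to a carbonyl group turns out to be a place where the number in this assay responds strongly: hydrogen in its place brings an at least 55-fold higher number from compound 2 to compound 3 (1.74 log units; beyond the scatter), whereas the replacement on an aromatic carbon gave only a 1.3-fold lower number from compound 1 to compound 2 (0.12 log units; within the scatter). Compound 3 gives > 100 mg/kg, which is a limit of the assay and not a number, so the step has a lower bound but no measured size. The comparison is therefore bounded from one side only, and it rests on a single value at that limit: the limit of > 100 mg/kg in this assay, at which 1 of the 3 values shown sits.

Only two ends are shown on this oxygen, 2-ethoxyethyl and hydrogen, so it stays open whether a shorter chain such as ethyl or a longer alkyl chain would keep the number near that of compound 2, and whether an amide in place of the ester would do the same. From the compounds shown here alone, it also stays open whether the same replacement would have a similar effect with the 3-(methoxymethyl)-1,2-oxazol-5-yl group of compound 1.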